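From a Butyl Chain to a Bare Nitrogen

A few compounds are considered here, and "the series" means these few. Any claim that something is new, unique, unknown or untested is made for them only; others in the source may bear on it.

Three compounds have numbers in a functional assay on OVCAR-3 cells (Homo sapiens) for inhibition; on this read-out higher numbers stand for weaker inhibition and lower numbers for stronger inhibition. Compound 1 `N#CC1CN1C(=O)Nc1ccc(Cl)c(Cl)c1` gives 5600 nM, compound 3 `N#CC1CN1C(=O)Nc1ccccc1` gives 6800 nM, and compound 2 `CCCCNC(=O)N1CC1C#N` gives 12000 nM. Compound 2 holds the highest of these three numbers; its gap to compound 3 lies within the usual scatter, while its gap to compound 1 lies beyond it. Compound 4 `N#CC1CN1C(N)=O` differs from compound 2 in one place: hydrogen in place of butyl on an amide-type nitrogen. Within the data shown here, no measured pair shows this kind of change, so nothing here tells how large its effect is. The expectation is that compound 4 inhibits no more strongly than compound 2, and the step of a 1.7-fold higher number from compound 2 to compound 4 (0.22 log units; within the scatter) is expected to be a modest rise. For compound 4 the estimate is 20000 nM, within a range from 8000 nM to 60000 nM, with a fair chance that this assay reports only a limit.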

Compound 4, half-maximal inhibitory concentration: > 90000 nM
Compound 4 gave a limit, no number; the forecaster's own chance of this, stated with the estimate: 30%; middle value at least 4.5-fold (0.65 log units) from the limit.
By their numbers in this assay, from the lowest: compounds 1, 3 and 2 (each within the scatter of the next, the first and the last beyond it). At a limit, above all of these: compound 4.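

Replacing butyl with hydrogen on this amide-type nitrogen gives an at least 7.5-fold higher number from compound 2 to compound 4 (0.87 log units; beyond the scatter) in this assay and shows that losing the group here can cost much of the inhibition. Each earlier compound carries a group on this nitrogen, so none of them could show this. Compound 4 gives only a limit, so the full size of the step stays unknown: the limit of > 90000 nM in this assay, at which 1 of the 4 values shown sits.

As far as these compounds go, it remains open whether a shorter chain such as ethyl would hold the inhibition seen with butyl. From the compounds shown here alone, how a butyl chain ending in an amine or a carboxylic acid would read also remains open.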